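Taking one methoxy away from compound 2

This account rests on a few compounds, and the source may have more. Where it says the series, first, only, none or still open, it means among the compounds named here.

Measured so far in a functional assay on MCF7 cells (Homo sapiens) for inhibition, read by sulforhodamine B assay, with a stated time of 48 h; a lower number here means a stronger inhibitor of growth, a higher number a weaker inhibitor of growth:
Compound 1 `CC1(/C=C/c2ccccc2)C=CC(=O)O1`: 95300 nM
Compound 2 `COc1ccc(/C=C/C2(C)C=CC(=O)O2)c(OC)c1`: 43500 nM
Compound 3 `COc1ccc(/C=C/C2(C)C=CC(=O)O2)c(OC)c1OC`: 110000 nM

Compound 2 has the lowest of these three numbers, and both of the others lie beyond the scatter from it. The next compound to be tested is compound 4 `COc1ccccc1/C=C/C1(C)C=CC(=O)O1`, which differs from compound 2 in one place: hydrogen in place of methoxy on an aromatic carbon. In short, hydrogen takes the place of methoxy on an aromatic carbon.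

For the measured compounds named here, only one measured step involves a single methoxy, and it adds one rather than taking one away: a 2.5-fold higher number from compound 2 to compound 3 (0.40 log units; beyond the scatter). That step is modest, and it concerns a different ring carbon, so it cannot simply be run backwards. Compound 1, which carries no methoxy at all, gives 95300 nM, also a higher number than that of compound 2. With so few compounds this is only a weak guide, but a modest rise in the number is expected in this assay, with a fall not ruled out. The expected change is a 1.6-fold higher number from compound 2 to compound 4 (0.21 log units; within the scatter). For compound 4 the estimated value is 70000 nM, with an expected range from 35000 nM to 140000 nM.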

Compound 4, concentration for total growth inhibition: 27000 nM
Estimate against measurement, compound 4: 2.6-fold (0.41 log units) above, outside the stated range (below it).
By their numbers in this assay, from the lowest: compounds 4 and 2 (each within the scatter of the next); then compounds 1 and 3 (each within the scatter of the next).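

In this assay, the methoxy on the aromatic carbon para to the group of 9 heavy atoms can be exchanged for hydrogen with no change beyond the scatter (the step is a 1.6-fold lower number from compound 2 to compound 4 (0.21 log units; within the scatter)), so compound 2 and compound 4 cannot be told apart. For the compounds shown here, the methoxy that compound 4 keeps is the one place where it differs from compound 1, and that change does register (the step is a 3.5-fold lower number from compound 1 to compound 4 (0.55 log units; beyond the scatter)), which the earlier compounds could not show. Methoxy in place of hydrogen therefore has no single effect in this small set, and the outcome depends on which ring carbon carries it and on the core it is added to: the same change on two cores in this assay, a 2.5-fold higher number (0.40 log units; beyond the scatter) from compound 2 to compound 3 and a 3.5-fold lower number (0.55 log units; beyond the scatter) from compound 1 to compound 4, 8.9-fold (0.95 log units) apart, beyond the scatter of two such steps.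

The compounds shown do not tell whether a different group on the carbon that lost its methoxy, such as a hydroxyl or an amine, would move the number beyond the scatter. They also leave open whether the step seen with the methoxy kept by compound 4 is specific to methoxy or would also appear with a chlorine or a longer ether chain in its place.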